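The compounds below may be only part of what the source reports. "The series", "measured", "known", "first", "only" and "open" are said of these compounds alone.

Working notes on the series. In a functional assay on Hep 3B2 cells (Homo sapiens) for inhibition, read by sulforhodamine B assay, with a stated time of 72 h (on this read-out higher numbers stand for weaker inhibition and lower numbers for stronger inhibition), compound 1 `C[C@H](Nc1nc(N)nc(N)c1C#N)c1nn(-c2cccc(S(C)(=O)=O)c2)c2cc(F)ccc12` gives 19700 nM. Compound 3 `C[C@H](Nc1ncnc2[nH]cnc12)c1nn(-c2cccnc2)c2cc(F)ccc12` gives 34500 nM in this assay. The value of compound 2 `C[C@H](Nc1ncnc2[nH]cnc12)c1nn(-c2cccnc2)c2cc(Cl)ccc12` in this assay is a limit, > 40000 nM. Within the data shown here, of the three values so far, one sits at the limit of > 40000 nM in this assay, at which 1 of the 3 values shown sits. The difference between the core of compound 1 and the core of compound 3 is not broken down here. Compound 3 and compound 2 are one step apart: chloro in place of fluoro on an aromatic carbon That step gives an at least 1.1-fold higher number from compound 3 to compound 2 (0.06 log units; that floor lies within the scatter), and since its floor lies within the scatter the two values cannot be ordered. Compound 4 `C[C@H](Nc1nc(N)nc(N)c1C#N)c1nn(-c2cccc(S(C)(=O)=O)c2)c2cc(Cl)ccc12` is not yet measured and stands to compound 1 as compound 2 stands to compound 3: chloro in place of fluoro on an aromatic carbon The change is the same in both pairs, down to its place on the ring. The expected step is a 1.3-fold higher number from compound 1 to compound 4 (0.10 log units; within the scatter), set beside the measured one because an at least 1.1-fold higher number from compound 3 to compound 2 (0.06 log units; that floor lies within the scatter) supplies only a floor inside the scatter and no sign of a larger shift. Compound 4 is therefore estimated at 25000 nM in this assay, with the range 12000 nM to 50000 nM.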

Compound 4, half-maximal inhibitory concentration: 5110 nM
The estimate for compound 4 lay 4.9-fold (0.69 log units) above the measured number; measured number below the stated range.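

In this assay, chloro in place of fluoro on the core of compound 1 gives a 3.9-fold lower number from compound 1 to compound 4 (0.59 log units; beyond the scatter), so on this core the change moves the number beyond the scatter. Among these compounds, the same change does not keep its size from one core to the other: the same change on two cores in this assay, an at least 1.1-fold higher number (0.06 log units; that floor lies within the scatter) from compound 3 to compound 2 and a 3.9-fold lower number (0.59 log units; beyond the scatter) from compound 1 to compound 4, at least 4.4-fold (0.65 log units) apart, beyond the scatter of two such steps Only two pairs support this, so it gives no reason for the gap and no rule for the series; the value of compound 2, > 40000 nM, is a limit of the assay and not a number.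

The two cores differ in more than one place, and the pairs shown change only the halogen, so it remains open which of those places sets the gap. Also open, on these data alone, is whether bromo or methyl on the same aromatic carbon would follow chloro on the core of compound 1, and whether the lower number of compound 4 would hold with an amine or a carboxylic acid in place of the methylsulfonyl group.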